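Ester side chain in place of the amine, compound 4

This account rests on a few compounds, and the source may have more. Where it says the series, first, only, none or still open, it means among the compounds named here.

Values in an assay on HL-60 cells for agonist activity at vitamin D3 receptor (Homo sapiens), read by microscopy, with a stated time of 96 h (on this read-out lower numbers stand for an effect already at smaller amounts and higher numbers for an effect only at larger amounts of compound), so far:
compound 1 `CCOC(=O)CN(C)C(=O)c1ccc(C(CC)(CC)c2ccc(OCC(=O)C(C)(C)C)c(C)c2)n1CC`: > 50000 nM
compound 2 `CCN(CC)CCCNC(=O)c1ccc(C(CC)(CC)c2ccc(OCC(=O)C(C)(C)C)c(C)c2)n1CC`: 22 nM
compound 3 `CCn1c(C(=O)NCCN)ccc1C(CC)(CC)c1ccc(OCC(=O)C(C)(C)C)c(C)c1`: 120 nM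

The value of compound 1 is a limit of this assay, not a number (the limit of > 50000 nM in this assay, at which 1 of the 3 values shown sits).

Compound 3 holds the higher of the two numbers. Its gap to the nearest measured compound is a 5.5-fold higher number from compound 2 to compound 3 (0.74 log units; beyond the scatter).

Compound 4 `CCOC(=O)CC(C)OC(=O)c1ccc(C(CC)(CC)c2ccc(OCC(=O)C(C)(C)C)c(C)c2)n1CC` is not yet measured. It differs from compound 3 in one place: a group of 9 heavy atoms (6 carbon, 3 oxygen; no ring) in place of a group of 4 heavy atoms (2 carbon, 2 nitrogen; no ring), on a carbonyl carbon. The entering chain carries no hydrogen-bond donor and no amine nitrogen, which brings compound 4 close in kind to compound 1, whose side chain likewise holds an ester and no amine. Among the compounds with values here, the steps that bear on this change are an at least 410-fold lower number from compound 1 to compound 3 (2.61 log units; beyond the scatter) and an at least 2200-fold lower number from compound 1 to compound 2 (3.35 log units; beyond the scatter), both large and both running from the ester-bearing compound to the amine-bearing ones. Read in reverse, a large upward step is therefore expected in this assay for compound 4, most likely back to the limit.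

The estimate for compound 4 is 40000 nM (range 4000 nM to 100000 nM), a step of a 330-fold higher number from compound 3 to compound 4 (2.52 log units; beyond the scatter) expected.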

Compound 4, half-maximal effective concentration: > 50000 nM
Compound 4: no number, only a limit (the forecaster's own chance of this, stated with the estimate: 70%); middle value at least 1.2-fold (0.09 log units) from the limit.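

In this assay the change gives an at least 410-fold higher number from compound 3 to compound 4 (2.61 log units; beyond the scatter) and an at least 2200-fold higher number from compound 2 to compound 4 (3.35 log units; beyond the scatter), so on this carbonyl carbon a second ester-bearing chain without an amine, joined through oxygen rather than through an amide nitrogen, matches the outcome of compound 1. The step from compound 1 to compound 4 cannot be read, since both values are limits. Compound 4 gives a limit, not a number, so among the four compounds both amine-bearing chains give numbers and both ester-bearing chains stop at the limit, with none going against this: the limit of > 50000 nM in this assay, at which 2 of the 4 values shown sit.

Still open, as far as these compounds go, is whether the amine or the ester governs this split, which a plain alkyl amide or a carboxylic acid on the same carbonyl carbon would help separate. From the compounds shown here alone, it is also open how a longer chain ending in a primary amine would compare with compound 3.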